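The source may hold more compounds than are shown below. What is called first, only, known or untested is meant among the compounds shown, and "the series" means these compounds.

Measured so far:
compound 1, `Cc1nn(C)c(Oc2ccc(Cl)cc2)c1/C=N\CCCCCOc1cc2oc(=O)cc(C)c2cc1Cl`, 17500 nM in a functional assay on SMMC-7721 cells (Homo sapiens) for antiproliferative activity, read by MTT assay, with a stated time of 72 h; a lower number here means a stronger inhibitor, a higher number a weaker inhibitor
compound 2, `Cc1nn(C)c(Oc2ccc(Br)cc2)c1/C=N\CCCCCOc1cc2oc(=O)cc(C)c2cc1Cl`, this assay: "not determined" (no result reported)
compound 3, `Cc1nn(C)c(Oc2ccc(F)c(F)c2)c1/C=N\CCCCCCOc1cc2oc(=O)cc(C)c2cc1Cl`, this assay: > 25000 nM

Compound 3 stands at the edge of what this assay reports. Its entry, > 25000 nM, is a limit of the assay and not a number, so only an upper bound on its potency is known. Going by the values given here, it shares that position with no other compound here, as the limit of > 25000 nM in this assay, at which 1 of the 3 values shown sits, shows: one of the three entries sits there. Among the compounds with values here, compound 1, the only compound with a single number, gives 17500 nM, which is itself a weak result. Compound 2 carries no result. Within the data shown here, compound 3 differs from compound 1 in more than one place, so no single step between them can be read.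

Compound 4, `Cc1ccc(Oc2c(/C=N\CCCCCCOc3cc4oc(=O)cc(C)c4cc3Cl)c(C)nn2C)cc1`, is not yet measured. It is reached from compound 3 by one change: 4-methylphenyl in place of 3,4-difluorophenyl on an oxygen on an aromatic ring. No measured step in this series resembles this change, so the expectation rests on the general weakness of the compounds shown. Compound 4 is estimated to stay in the same weak region, with an at least 1.1-fold lower number from compound 3 to compound 4 (0.05 log units; that floor lies within the scatter) amounting to no step beyond the scatter. Compound 4 is expected to give about 22000 nM, most likely between 8000 nM and 45000 nM.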

Compound 4, half-maximal inhibitory concentration: 18600 nM
Beside the measured number, compound 4's estimate is 1.2-fold (0.07 log units) above it; the measured number falls inside the stated range.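

In this assay, the change from 3,4-difluorophenoxy to 4-methylphenoxy gives the series its first readable step at this position, on an oxygen on an aromatic ring: an at least 1.3-fold lower number from compound 3 to compound 4 (0.12 log units; that floor lies within the scatter). That step is only a floor, and compound 3 holds a limit of the assay and not a number, > 25000 nM: the limit of > 25000 nM in this assay, at which 1 of the 4 values shown sits. Compound 4, at 18600 nM, supplies the only single number among the compounds shown that share the chain of compound 3, so this position now has one measured anchor, although the step does not show that the swap of the two aryl groups moves the result beyond the scatter.

The compounds shown leave open whether any group on this aromatic ring can move the number clearly, for example an amine or a carboxylic acid in place of the methyl of compound 4. They also leave open how the 4-methylphenoxy group would read on a shorter or a longer chain, and whether the chain itself matters at all, since no pair shown differs in the chain alone.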